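The source may hold more compounds than are shown below. What is called first, only, known or untested is meant among the compounds shown, and "the series" means these compounds.

Compound 2 `COc1ccc(C(=O)/C=C/c2ccc(O)c(OC)c2)cc1` stands highest of the three numbers in an assay on RBL-1 cells for inhibition of Polyunsaturated fatty acid 5-lipoxygenase (Rattus norvegicus) (a higher number here means a weaker inhibitor, a lower number a stronger inhibitor), giving 12000 nM. Within the data shown here, compound 1 `O=C(/C=C/c1ccc(O)c(O)c1)c1ccccc1-c1cccnc1` gives 210 nM and compound 3 `COc1ccccc1C(=O)/C=C/c1ccc(O)c(O)c1` gives 27 nM; the one measured step between them, a 7.8-fold lower number from compound 1 to compound 3 (0.89 log units; beyond the scatter), alters the other ring and leaves the position changed here untouched. Compound 4 `COc1ccc(C(=O)/C=C/c2ccc(O)c(O)c2)cc1` differs from compound 2 by hydrogen in place of methyl on an oxygen on an aromatic ring, so compound 4 carries the hydroxy that compound 1 and compound 3 also carry. Among the measured compounds shown here, no measured step covers this change directly, yet compound 1 and compound 3, both with that hydroxy in place, lie far below compound 2 in this assay. On that basis a large downward step is expected, about a 60-fold lower number from compound 2 to compound 4 (1.78 log units; beyond the scatter). Compound 4 is estimated at 200 nM, in a range from 40 nM to 1500 nM.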

Compound 4, half-maximal inhibitory concentration: 20 nM
For compound 4 the middle estimate is 10-fold (1.00 log units) above the measured one; measured number outside the range, below it.
By their numbers in this assay, from the lowest: compounds 4 and 3 (each within the scatter of the next); then compound 1; then compound 2.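

In this assay, among these compounds, replacing methoxy with hydroxy on an oxygen on an aromatic ring gives a 600-fold lower number from compound 2 to compound 4 (2.78 log units; beyond the scatter), far larger than the only earlier step. Among the compounds shown here, compound 1 and compound 3 both carried the hydroxy, so this is the first direct reading of what the methyl on this oxygen costs. Nothing measured here explains the size of this step.

The compounds shown leave open how an ethyl group or a longer chain on this oxygen would compare. They also leave open whether an amine in place of the hydroxy would keep the number low.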